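Urea series: aryl substituent swap, iodo for methoxy

The compounds below may be only part of what the source reports. "The series", "measured", "known", "first", "only" and "open" are said of these compounds alone.

Compound 1 `CC(C)c1cccc(NC(=O)N[C@H](C)c2ccccc2)c1`: 44%
Compound 2 `CCOC(=O)c1cccc(NC(=O)N[C@H](C)c2ccccc2)c1`: 88%
Compound 3 `COc1cccc(NC(=O)N[C@H](C)c2ccccc2)c1`: 70%

In an ADME assay on the whole organism with Oryza sativa as the target, tested at 10 uM (a higher number here means a weaker effect of the compound at the concentration tested, a lower number a stronger effect), compound 3 sits second highest of the three: a number 18 percentage points lower from compound 2 to compound 3 (beyond the scatter), and a number 26 percentage points higher from compound 1 to compound 3 (beyond the scatter). The whole spread runs a number 44 percentage points higher from compound 1 to compound 2 (beyond the scatter).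

Compound 4 `C[C@@H](NC(=O)Nc1cccc(I)c1)c1ccccc1` carries the change (iodo in place of methoxy on an aromatic carbon). Within the data shown here, no measured step exchanges a halogen, so neither step bears on it directly; both show that a single change on that aromatic carbon moves the read-out by a modest to large amount. Iodo, like isopropyl in compound 1, brings no hydrogen-bond acceptor, so a modest fall below compound 3 is expected, roughly a number 15 percentage points lower from compound 3 to compound 4 (beyond the scatter). Compound 4 is estimated at 55%, range 35% to 80%.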

Compound 4, a percentage reported as activity, at one concentration (the size of the read-out at that concentration, not a potency): 73%
Estimate against measurement, compound 4: 18 percentage points below; the measured number falls inside the stated range.
By their numbers in this assay, from the lowest: compound 1; then compounds 3 and 4 (each within the scatter of the next); then compound 2.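

In this assay, among these compounds, iodo in place of methoxy on this aromatic carbon gives a number 3 percentage points higher from compound 3 to compound 4 (within the scatter) and is the first change here that leaves the read-out within the scatter. Iodo and isopropyl both bring no hydrogen-bond acceptor, yet a number 29 percentage points higher from compound 1 to compound 4 (beyond the scatter) separates them, so the lack of an acceptor alone does not set the read-out at this position. Ethoxycarbonyl also stays apart from iodo, with a number 15 percentage points lower from compound 2 to compound 4 (beyond the scatter) as the step.

From the compounds shown here alone, whether bromo, an amine or a carboxylic acid on this aromatic carbon would fall with iodo and methoxy remains open. No measurement on hand gives a cause for these steps.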